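The source may hold more compounds than are shown below. What is called first, only, known or untested is meant among the compounds shown, and "the series" means these compounds.

In an ADME assay on HepG2 cells (Homo sapiens) for cytotoxicity, read by luminescence, CellTiter-Glo and ATP content, with a stated time of 72 h (a higher number here means that more compound is needed for the effect, a lower number that less compound is needed), the three measured compounds stand as follows:

compound 1, `COc1ccc(F)cc1CNCCCNc1ccnc2cc(Cc3ccc(F)cc3Cl)ccc12`, 2460 nM
compound 2, `COc1ccc(F)cc1CNCCCNc1ccnc2cc(Oc3ccc(F)cc3)ccc12`, 6600 nM
compound 3, `COc1ccc(F)cc1CNCCCNc1ccnc2cc(-c3ccc(C(F)(F)F)cc3)ccc12`, 5190 nM

Compound 3 has the second highest of the three numbers. Its nearest neighbour is compound 2, and the gap a 1.3-fold lower number from compound 2 to compound 3 (0.10 log units; within the scatter) lies within the scatter, so the two cannot be ordered. Its furthest is compound 1, from which a 2.1-fold higher number from compound 1 to compound 3 (0.32 log units; beyond the scatter) separates it beyond the scatter; compound 1 also sits apart from compound 2 by a 2.7-fold higher number from compound 1 to compound 2 (0.43 log units; beyond the scatter).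

Compound 4, `COc1ccc(F)cc1CNCCCNc1ccnc2cc(Oc3cccc(N(C)C)c3)ccc12`, has not yet been measured. It differs from compound 3 in one place: 3-(dimethylamino)phenoxy in place of 4-(trifluoromethyl)phenyl on an aromatic carbon. Within the data shown here, the step that bears most directly on this is the one between compound 2 and compound 3, since it also exchanges a phenyl group for a phenoxy group at the same aromatic carbon and gave a difference within the scatter. Among the measured compounds shown here, the change to compound 4 keeps the phenoxy attachment of compound 2 but carries a dimethylamino substituent in place of fluorine, for which no measured pair offers guidance.

Given this, the step of a 1.2-fold higher number from compound 3 to compound 4 (0.06 log units; within the scatter) is expected to stay within the scatter, in no firm direction. Compound 4 is therefore estimated to give 6000 nM in this assay, with a range from 2500 nM to 14000 nM.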

Compound 4, half-maximal effective concentration in the HepG2 assay: 3300 nM
Compound 4: the middle estimate sits 1.8-fold (0.26 log units) above what was measured, within the range that was stated.
By their numbers in the HepG2 assay, from the lowest: compounds 1, 4, 3 and 2 (each within the scatter of the next, the first and the last beyond it).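

In the HepG2 assay, the 3-(dimethylamino)phenoxy group leaves compound 4 within the scatter of all three earlier compounds at this aromatic carbon, with the steps reading a 1.6-fold lower number from compound 3 to compound 4 (0.20 log units; within the scatter), a 2.0-fold lower number from compound 2 to compound 4 (0.30 log units; within the scatter) and a 1.3-fold higher number from compound 1 to compound 4 (0.13 log units; within the scatter). In a physicochemical assay for solubility, with a stated time of 18 h, at pH 7.4 (a lower number here means a less soluble compound, a higher number a more soluble compound), compound 3 gives 32000 nM and compound 4 gives 14500 nM. The exchange of 4-(trifluoromethyl)phenyl for 3-(dimethylamino)phenoxy therefore separates the two compounds by lower solubility, although it does not separate them beyond the scatter in the HepG2 assay: the measured solubility of compound 3, 32000 nM, and of compound 4, 14500 nM, a 2.2-fold lower number (0.34 log units; beyond the scatter)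

The compounds shown leave open whether the lower solubility goes with the oxygen attachment or with the dimethylamino substituent, as the two enter together between this pair. They also do not show how a carboxylic acid or a morpholine on the phenoxy ring, or a dimethylamino group on a directly attached phenyl ring, would stand in either measurement.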